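Difluorophenyl on the Ring Nitrogen of a Nitrate-Bearing Analogue

A few compounds are considered here, and "the series" means these few. Any claim that something is new, unique, unknown or untested is made for them only; others in the source may bear on it.

Compound 1, `Cc1c(CCSCCO)cc(-c2ccc(S(C)(=O)=O)cc2)n1-c1ccc(F)c(F)c1`, in an assay on J774 cells for inhibition of prostaglandin G/H synthase 1 (Mus musculus), read by immunoassay, with stated times of 15 min and 30 min; a lower number here means a stronger inhibitor, a higher number a weaker inhibitor: > 10000 nM, which is a limit of the assay rather than a number.
Compound 2, `Cc1c(CC[S+]([O-])CCO[N+](=O)[O-])cc(-c2ccc(S(C)(=O)=O)cc2)n1-c1ccccc1`, in this assay: > 10000 nM, again a limit of the assay.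

Compound 2 thus sits at the limit, as does every value shown here (the limit of > 10000 nM in this assay, at which 2 of the 2 values shown sit). Compound 3, `Cc1c(CC[S+]([O-])CCO[N+](=O)[O-])cc(-c2ccc(S(C)(=O)=O)cc2)n1-c1ccc(F)c(F)c1`, differs from compound 2 in one place: 3,4-difluorophenyl in place of phenyl on an aromatic nitrogen. No measured step of this kind exists among these compounds, so no shift beyond the usual scatter is expected, and another limit seems the most probable outcome. Compound 3 is therefore estimated at 20000 nM, with a range from 8000 nM to 60000 nM. The expected step is a step that the limit leaves unreadable from compound 2 to compound 3.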

Compound 3, half-maximal inhibitory concentration: > 10000 nM
Compound 3 gave a limit, no number; the forecaster's own chance of this, stated with the estimate: 85%; the middle value lies beyond the limit too.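

No step can be read between compound 1, compound 2 and compound 3, since each result is a limit and not a number: the limit of > 10000 nM in this assay, at which 3 of the 3 values shown sit. From the compounds shown here alone, how strongly any of the three inhibits in this assay, and whether 3,4-difluorophenyl in place of phenyl changes that, stays open.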